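Ether chain shortening on the aminoquinoline series

The source may hold more compounds than are shown below. What is called first, only, known or untested is meant among the compounds shown, and "the series" means these compounds.

The series shares one core; compound 1 `CCCCCCOc1ccc2c(Cl)ccnc2c1` and compound 3 `CC(C)COc1ccc2c(Cl)ccnc2c1` carry a chloro substituent, whereas compound 2 `C=CCOc1ccc2c(NCCCN(C)C)ccnc2c1` carries the dimethylaminopropylamino chain. In a functional assay on HepG2 cells (Homo sapiens) for cytotoxicity, read by MTT assay, with a stated time of 48 h (on this read-out lower numbers stand for stronger inhibition and higher numbers for weaker inhibition), compound 1 gives 2420 nM, compound 3 gives 2250 nM and compound 2 gives 3990 nM. The gaps from compound 2 to compound 1 and to compound 3 are both within the usual scatter, so compound 2 cannot be set apart from either on these numbers.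

Compound 4 `CCOc1ccc2c(NCCCN(C)C)ccnc2c1` is not yet measured. It differs from compound 2 as follows: methyl in place of vinyl on a saturated chain carbon bound to an oxygen on an aromatic ring.

Going by the values given here, the only measured step at the same place is a 1.1-fold lower number from compound 1 to compound 3 (0.03 log units; within the scatter), a change of the chain on a saturated chain carbon bound to an oxygen on an aromatic ring that left the read-out within the scatter. The change from compound 2 to compound 4 is a smaller trimming of the same chain, and the two compounds share every other feature. On that basis no step beyond the scatter is expected in this assay in either direction.

Compound 4 is therefore expected to give about 3800 nM in this assay, with a range from 1900 nM to 7600 nM. The expected step is a 1.1-fold lower number from compound 2 to compound 4 (0.02 log units; within the scatter).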

Compound 4, half-maximal inhibitory concentration: 5860 nM
Compound 4: middle estimate off by 1.5-fold (0.19 log units), on the low side; the measured number falls inside the stated range.
By their numbers in this assay, from the lowest: compounds 3, 1, 2 and 4 (each within the scatter of the next, the first and the last beyond it).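

In this assay, going by these compounds alone, the allyloxy to ethoxy change gives a 1.5-fold higher number from compound 2 to compound 4 (0.17 log units; within the scatter), so removing the double bond from this ether chain produces no step that can be separated from the scatter. The earlier step at this place, a 1.1-fold lower number from compound 1 to compound 3 (0.03 log units; within the scatter), came from the chloro compounds; this pair extends the same reading to compounds carrying the dimethylaminopropylamino chain, and within the four compounds shown, neither step on a saturated chain carbon bound to an oxygen on an aromatic ring leaves the scatter. Within the data shown here, compound 3 and compound 4 are the only pair at the two ends of the order that lie beyond the scatter of each other, but they differ in more than one place, so that gap says nothing about this ether chain, and no supporting data bear on the result.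

The compounds shown leave open whether a longer chain on the ether oxygen, or a chain ending in an amine or a carboxylic acid, would move the number in this assay beyond the scatter on the dimethylaminopropylamino side. Among these compounds, they also hold no pair that differs only in chloro against the dimethylaminopropylamino chain, so the contribution of that chain cannot be read from them.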